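Amide aryl exchange in a chloro-substituted anilide series

This account rests on a few compounds, and the source may have more. Where it says the series, first, only, none or still open, it means among the compounds named here.

Measured so far:
compound 1, `O=C(Nc1ccc(Cl)c(-c2nnc3c(Cl)cccn23)c1)c1ccc(Cl)cc1`, gives 58400 nM in a functional assay on MCF7 cells (Homo sapiens) for antiproliferative activity, read by MTT assay, with a stated time of 72 h; a lower number here means a stronger inhibitor, a higher number a weaker inhibitor
compound 2, `O=C(Nc1ccc(Cl)c(-c2nnc3c(Cl)cccn23)c1)c1cccc(Cl)c1`, gives 71900 nM in this assay

Both measured compounds share the same core and differ only in the aryl group on the carbonyl carbon. Compound 2 carries the number at the top of this pair, but the pair is not separated: the step of a 1.2-fold higher number from compound 1 to compound 2 (0.09 log units; within the scatter) is within the scatter, so the two compounds are read as equivalent in this assay.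

Compound 3, `CS(=O)(=O)c1ccc(C(=O)Nc2ccc(Cl)c(-c3nnc4c(Cl)cccn34)c2)cc1`, is the next entry. Its difference from compound 2 is 4-(methylsulfonyl)phenyl in place of 3-chlorophenyl on a carbonyl carbon. Within the data shown here, the only measured step, a 1.2-fold higher number from compound 1 to compound 2 (0.09 log units; within the scatter), moves a chlorine within the same aryl group and says nothing about a methylsulfonyl group entering in place of the chlorine; no measured step therefore bears on this change. The expectation for compound 3 rests on the level of compound 2 alone, so the step expected is a 1.3-fold higher number from compound 2 to compound 3 (0.10 log units; within the scatter), with a wide range. The estimate for compound 3 in this assay is 90000 nM, expected to fall between 30000 nM and 250000 nM.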

Compound 3, half-maximal inhibitory concentration: 94200 nM
For compound 3 the middle estimate is 1.0-fold (0.02 log units) below the measured one; the range from low to high includes it.
By their numbers in this assay, from the lowest: compounds 1, 2 and 3 (each within the scatter of the next).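

The step of a 1.3-fold higher number from compound 2 to compound 3 (0.12 log units; within the scatter) in this assay comes with 4-(methylsulfonyl)phenyl in place of 3-chlorophenyl on the carbonyl carbon and stays within the scatter, as does a 1.6-fold higher number from compound 1 to compound 3 (0.21 log units; within the scatter) for methylsulfonyl in place of chloro on an aromatic carbon. The earlier pair only showed a chlorine changing its place on the aryl group; this result shows that a different substituent can enter, taking the aryl group from 7 to 10 heavy atoms and from 0 to 2 hydrogen-bond acceptors, with no step beyond the scatter, so all three compounds read as one level. Nothing at hand explains why this exchange leaves the level unresolved from the others.

Open, on these data alone, is whether any group on this aryl ring separates from that level, for instance an amine or a carboxylic acid, or whether a longer alkyl chain on the carbonyl carbon in place of the aryl group would do so. Also open, as far as these compounds go, is how much the chlorines on the shared core contribute, since all three compounds carry them unchanged.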